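From Cyclopropyl to Benzyl on a Shared Core

This account rests on a few compounds, and the source may have more. Where it says the series, first, only, none or still open, it means among the compounds named here.

Measured in a physicochemical assay for solubility, in phosphate buffer, measured as kinetic solubility; a lower number here means a less soluble compound, a higher number a more soluble compound:
- Compound 1 `CC(C)[C@@H](c1ccc(-c2ccc3cccc(F)c3c2)[nH]c1=O)[C@@H]1OC(=O)NC1=O`: 27400 nM
- Compound 2 `CCC(/C=C1\OC(=O)NC1=O)(CC)c1ccc(-c2ccc3cccc(F)c3c2)[nH]c1=O`: 32600 nM
- Compound 3 `O=C1NC(=O)/C(=C/C(c2ccc(-c3ccc4cccc(F)c4c3)[nH]c2=O)C2CC2)O1`: 30800 nM

All three values lie within the usual scatter of one another, so compound 3 stands level with the other two. Compound 4 `O=C1NC(=O)/C(=C/C(Cc2ccccc2)c2ccc(-c3ccc4cccc(F)c4c3)[nH]c2=O)O1` has benzyl in place of cyclopropyl on a saturated chain carbon bound to an aromatic carbon and a double-bonded chain carbon. Among the measured compounds shown here, no measured pair differs in one place only, so the data offer no direct guide. In this assay a small downward move is expected, though the direction is only a cautious guess. The modest size rests on compound 1 at 27400 nM and compound 2 at 32600 nM, which carry other groups in this region yet stay within the scatter of compound 3. The estimated change is a 1.5-fold lower number from compound 3 to compound 4 (0.19 log units; within the scatter). For compound 4 the estimated value is 20000 nM, with an expected range of 9000 nM to 36000 nM.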

Compound 4, solubility: 9100 nM
The estimate for compound 4 lay 2.2-fold (0.34 log units) above the measured number; low and high end bracket the measured number.
By their numbers in this assay, from the lowest: compound 4; then compounds 1, 3 and 2 (each within the scatter of the next).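

In this assay, putting benzyl in place of cyclopropyl on a saturated chain carbon bound to an aromatic carbon and a double-bonded chain carbon gives a 3.4-fold lower number from compound 3 to compound 4 (0.53 log units; beyond the scatter) and is a change beyond the scatter. Among the compounds shown here, the three earlier compounds stand level but differ in more than one place, so only this step shows that the group at this position can move the number. No measurement here accounts for the drop.

A single step cannot separate the effect of the aromatic ring from that of the added carbons. As far as these compounds go, how an amine, a carboxylic acid or a longer chain at this carbon would behave remains open.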